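A few compounds are considered here, and "the series" means these few. Any claim that something is new, unique, unknown or untested is made for them only; others in the source may bear on it.

In a physicochemical assay for solubility, at pH 7.4 (a lower number here means a less soluble compound, a higher number a more soluble compound), two compounds with a shared core have been measured so far. Compound 1 `CCOCc1nc(Nc2ccc(C(F)(F)F)cc2)c2ccc(-c3ncccc3C(F)(F)F)cc2n1` gives 0.6 ug/mL as its reading, and compound 2 `O=C(O)CCc1nc(Nc2ccc(C(F)(F)F)cc2)c2ccc(-c3ncccc3C(F)(F)F)cc2n1` gives 125 ug/mL as the higher of these two numbers. Compound 3 `CNCc1nc(Nc2ccc(C(F)(F)F)cc2)c2ccc(-c3ncccc3C(F)(F)F)cc2n1` keeps that core but has not yet been measured. Its difference from compound 2 is methylamino in place of carboxymethyl on a saturated chain carbon bound to an aromatic carbon in one place: methylamino in place of carboxymethyl on a saturated chain carbon bound to an aromatic carbon. Among the compounds with values here, the only measured step at this place is a 210-fold higher number from compound 1 to compound 2 (2.32 log units; beyond the scatter) and it is large, well beyond the scatter. That step shows that this assay can move far with a change on this carbon, yet it never tests methylamino, so any forecast is loose. The expected step is a 4.2-fold lower number from compound 2 to compound 3 (0.62 log units; beyond the scatter) as an estimate, smaller than the measured one. For compound 3 the estimated value is 30 ug/mL with 6 ug/mL to 120 ug/mL as the expected range.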

Compound 3, solubility: 10 ug/mL
Estimate against measurement, compound 3: 3.0-fold (0.48 log units) above; low and high end bracket the measured number.
By their numbers in this assay, from the lowest: compound 1; then compound 3; then compound 2.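

In this assay, a third group on this saturated chain carbon gives a reading that matches neither earlier compound: methylamino in place of carboxymethyl gives a large drop (a 13-fold lower number from compound 2 to compound 3 (1.10 log units; beyond the scatter)), while methylamino in place of ethoxy gives a large rise (a 17-fold higher number from compound 1 to compound 3 (1.22 log units; beyond the scatter)). The position therefore shows three separate levels rather than two, with compound 3 lying between compound 1 and compound 2 and every gap beyond the scatter. No other measurement accompanies these readings to explain the order.

With only one amine and one carboxylic acid among these compounds, it remains open how far each reading belongs to that particular group. A dimethylamino group, a primary amine or a longer chain carrying the methylamino group could show whether the level of compound 3 holds.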